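This account rests on a few compounds, and the source may have more. Where it says the series, first, only, none or still open, it means among the compounds named here.

In a functional assay on EA.hy 926 cells (Homo sapiens) for cytotoxicity, read by MTT assay, with stated times of 24 h and 12 h, tested at 50 uM (on this read-out higher numbers stand for a stronger effect at the one concentration tested and lower numbers for a weaker effect), compound 1 `COc1ccc(/C=C/C(=O)O)c(OC(=O)c2nc(C)c(C)nc2C)c1` gives 31.6%. Compound 2 `CCOC(=O)/C=C/c1ccc(OC)cc1OC(=O)c1nc(C)c(C)nc1C` differs from it by ethyl in place of hydrogen on an oxygen next to a carbonyl group, and in this assay compound 2 gives 20.7%, a step of a number 10.9 percentage points lower from compound 1 to compound 2 (beyond the scatter). Compound 3 `Cc1nc(C)c(C(=O)Oc2cccc(/C=C/C(=O)O)c2)nc1C` rests on a different core, and the difference between the two cores is not broken down here; in this assay compound 3 gives 75.3%, the highest of the three numbers. Compound 4 `CCOC(=O)/C=C/c1cccc(OC(=O)c2nc(C)c(C)nc2C)c1` is not yet measured and differs from compound 3 by ethyl in place of hydrogen on an oxygen next to a carbonyl group, the same change that links compound 1 and compound 2. Because of the earlier step of a number 10.9 percentage points lower from compound 1 to compound 2 (beyond the scatter), compound 4 is expected to show a step of a number 11.3 percentage points lower from compound 3 to compound 4 (beyond the scatter). On that basis compound 4 is estimated at 64%, probably between 46% and 80%.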

Compound 4, a percentage reported as activity, at one concentration (the size of the read-out at that concentration, not a potency): 39.5%
Estimate against measurement, compound 4: 24.5 percentage points above, outside the stated range (below it).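

In this assay, putting ethyl in place of the hydrogen on the carboxy oxygen lowers the number on both cores, and here it gives a number 35.8 percentage points lower from compound 3 to compound 4 (beyond the scatter). The direction of the change therefore carries over between these two pairs, but its size does not: the same change on two cores in this assay, a number 10.9 percentage points lower (beyond the scatter) from compound 1 to compound 2 and a number 35.8 percentage points lower (beyond the scatter) from compound 3 to compound 4, 24.9 percentage points apart, beyond the scatter of two such steps. Two pairs cannot show why the cores differ or predict the step on a further core, and readings at a single concentration say nothing about potency.

The compounds shown carry only the carboxy and ethoxycarbonyl forms at this place. From the compounds shown here alone, how a methyl ester, an amide or a longer ester chain would compare on either core remains open.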